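The compounds below may be only part of what the source reports. "The series", "measured", "known", "first", "only" and "open" are said of these compounds alone.

The series rests on a shared core carrying a carbamate and a hydroxypropyl chain, tested in a functional assay on PANC-1 cells (Homo sapiens) for inhibition, read by MTT assay, with a stated time of 24 h, tested at 10 uM; on this read-out lower numbers stand for less inhibition and higher numbers for more inhibition at the one concentration tested (going by the name of the read-out). Compound 1 `CC(C)=CCC1Cc2c(OC(=O)Nc3ccc(F)cc3)cc(=O)n(CCCO)c2CC1(C)C` gives 0%. Compound 2 `CC(C)=CCC1Cc2c(OC(=O)Nc3cccc(F)c3)cc(=O)n(CCCO)c2CC1(C)C` gives 0%. Compound 3 `CC(C)=CCC/C(C)=C/CC1Cc2c(OC(=O)Nc3ccc(F)cc3)cc(=O)n(CCCO)c2CC1(C)C` gives 6.2%. Compound 4 `CC(C)=CCC/C(C)=C/CC1Cc2c(OC(=O)Nc3cccc(F)c3)cc(=O)n(CCCO)c2CC1(C)C` has not yet been measured.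

Compound 2 differs from compound 1 by 3-fluorophenyl in place of 4-fluorophenyl on an amide-type nitrogen, and that change produced no change at the digits printed from compound 1 to compound 2 (within the scatter). Compound 3 differs from compound 1 by 3-methylbut-2-en-1-yl in place of hydrogen on a saturated chain carbon bound to a double-bonded chain carbon, which produced a number 6.2 percentage points higher from compound 1 to compound 3 (within the scatter). Compound 4 differs from compound 3 by 3-fluorophenyl in place of 4-fluorophenyl on an amide-type nitrogen, the same change that was made from compound 1 to compound 2, at a place described in identical words, so it is the same change on a core that differs by the chain just described.

For the measured compounds named here, with only one earlier instance of this change, and that one flat, the step from compound 3 to compound 4 is expected to be about a number 1.2 percentage points lower from compound 3 to compound 4 (within the scatter) in this assay, because compound 1 to compound 2 gave no change at the digits printed from compound 1 to compound 2 (within the scatter). Compound 4 is therefore estimated at 5%, between 0% and 16%.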

Compound 4, a percentage reported as inhibition, at one concentration (the size of the read-out at that concentration, not a potency): 0%
Compound 4: middle estimate off by 5 percentage points, on the high side; the measured number falls inside the stated range.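

In this assay, 3-fluorophenyl in place of 4-fluorophenyl on the amide-type nitrogen gives a number 6.2 percentage points lower from compound 3 to compound 4 (within the scatter), and this step does not stand apart from the earlier one on the other core: the same change on two cores in this assay, no change at the digits printed (within the scatter) from compound 1 to compound 2 and a number 6.2 percentage points lower (within the scatter) from compound 3 to compound 4, 6.2 percentage points apart, within the scatter of two such steps. The added 3-methylbut-2-en-1-yl reads the same way, giving no change at the digits printed from compound 2 to compound 4 (within the scatter), which also does not stand apart from its earlier instance: the same change on two cores in this assay, a number 6.2 percentage points higher (within the scatter) from compound 1 to compound 3 and no change at the digits printed (within the scatter) from compound 2 to compound 4, 6.2 percentage points apart, within the scatter of two such steps. This shows that both changes stay within the scatter on both cores, but it does not show that either change carries over in any stronger sense. Every step here is too small to reveal a real effect that could be compared between the two cores.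

From the compounds shown here alone, whether the swap of fluorine position would matter on a compound with a number clearly above these remains open. So does whether a plain phenyl or a 3-chlorophenyl on the amide-type nitrogen, or an amine in place of the hydroxyl on the hydroxypropyl chain, would move the read-out at all.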